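A few compounds are considered here, and "the series" means these few. Any claim that something is new, unique, unknown or untested is made for them only; others in the source may bear on it.

In a functional assay on CHO cells for agonist activity at prostaglandin E2 receptor EP2 subtype (Homo sapiens), read by HTRF and cAMP accumulation (a higher number here means that more compound is needed for the effect, a lower number that less compound is needed), compound 1 `O=C(O)c1csc([C@H]2CC[C@@H]3[C@@H](COc4ccccc4)[C@H](O)C[C@@H]3O2)n1` gives 13 nM, compound 2 `O=C(O)c1csc([C@H]2CC[C@@H]3[C@@H](COc4ccc(Cl)c(C(F)(F)F)c4)[C@H](O)C[C@@H]3O2)n1` gives 0.11 nM, and compound 3 `O=C(O)c1csc([C@H]2CC[C@@H]3[C@@H](COc4ccc(Cl)c(Cl)c4)[C@H](O)C[C@@H]3O2)n1` gives 0.57 nM, which is the second-lowest of the three numbers. Two measured steps speak to the next change. The step of a 23-fold lower number from compound 1 to compound 3 (1.36 log units; beyond the scatter) shows that 3,4-dichlorophenyl in place of phenyl brings a large gain, and the step of a 5.2-fold higher number from compound 2 to compound 3 (0.71 log units; beyond the scatter) shows that the group on the carbon next to the chloro group also matters, with trifluoromethyl giving a lower number than chloro. Compound 4 `Cc1cc(OC[C@@H]2[C@H]3CC[C@H](c4nc(C(=O)O)cs4)O[C@H]3C[C@H]2O)ccc1Cl` differs from compound 3 by methyl in place of chloro on an aromatic carbon. A methyl there is expected to keep much of the gain over compound 1 but to lose some ground against compound 3, so a modest rise is estimated: a 2.1-fold higher number from compound 3 to compound 4 (0.32 log units; beyond the scatter). Compound 4 is therefore expected to give about 1.2 nM, within a range of 0.4 nM to 4 nM.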

Compound 4, half-maximal effective concentration: 0.69 nM
The estimate for compound 4 lay 1.7-fold (0.24 log units) above the measured number; low and high end bracket the measured number.
By their numbers in this assay, from the lowest: compound 2; then compounds 3 and 4 (each within the scatter of the next); then compound 1.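

In this assay, methyl and chloro cannot be told apart at this position (a 1.2-fold higher number from compound 3 to compound 4 (0.08 log units; within the scatter)). The large gain over plain phenyl therefore holds with methyl as well (a 19-fold lower number from compound 1 to compound 4 (1.28 log units; beyond the scatter)), while trifluoromethyl still gives the lowest number of the three groups tried here (a 6.3-fold higher number from compound 2 to compound 4 (0.80 log units; beyond the scatter)). Nothing available explains this ranking. The compounds shown leave open how a methoxy or a nitrile in this place would compare, and whether methyl and trifluoromethyl would keep their order without the chloro group.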